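Fluoro added to the anilide-side ring of compound 2

A few compounds are considered here, and "the series" means these few. Any claim that something is new, unique, unknown or untested is made for them only; others in the source may bear on it.

Going by the values given here, compound 2 `O=C(Nc1ccc(Oc2ccnc3[nH]ccc23)cc1)c1nn(-c2ccc(Br)cc2F)ccc1=O` gives 17900 nM in a functional assay on MCF7 cells (Homo sapiens) for cytotoxicity, read by MTT assay, with a stated time of 72 h (a higher number here means a weaker inhibitor, a lower number a stronger inhibitor), the highest of the three numbers so far. Compound 1 `O=C(Nc1ccc(Oc2ccnc3[nH]ccc23)cc1)c1nn(-c2ccccc2)ccc1=O` gives 15600 nM and compound 3 `O=C(Nc1ccc(Oc2ccnc3[nH]ccc23)cc1)c1nn(-c2ccc(Cl)c(C(F)(F)F)c2)ccc1=O` gives 6270 nM in this assay. The measured steps of a 1.1-fold higher number from compound 1 to compound 2 (0.06 log units; within the scatter), a 2.5-fold lower number from compound 1 to compound 3 (0.40 log units; beyond the scatter) and a 2.9-fold lower number from compound 2 to compound 3 (0.46 log units; beyond the scatter) all alter the aryl group on the aromatic nitrogen. Compound 4 `O=C(Nc1ccc(Oc2ccnc3[nH]ccc23)c(F)c1)c1nn(-c2ccc(Br)cc2F)ccc1=O` differs from compound 2 elsewhere: fluoro in place of hydrogen on an aromatic carbon. Among the compounds with values here, no measured step touches that ring, so the data give no guide to its effect. The expected step is therefore within the scatter, a 1.2-fold lower number from compound 2 to compound 4 (0.08 log units; within the scatter). Compound 4 is estimated at 15000 nM in this assay, with a range of 6000 nM to 40000 nM.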

Compound 4, half-maximal inhibitory concentration: 23500 nM
Compound 4: the middle estimate sits 1.6-fold (0.19 log units) below what was measured, within the range that was stated.
By their numbers in this assay, from the lowest: compound 3; then compounds 1, 2 and 4 (each within the scatter of the next).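

The first change away from the aryl group on the aromatic nitrogen, fluoro in place of hydrogen on an aromatic carbon, ortho to a large group and meta to a large group, gives a 1.3-fold higher number from compound 2 to compound 4 (0.12 log units; within the scatter) in this assay. This position therefore accepts fluoro without a change beyond the scatter, at least on the background of compound 2. Nothing available bears on the reason for this result.

On these data alone, whether methoxy or an amine at this position would give a step beyond the scatter remains open. So does whether fluoro here gives a similar step alongside the 4-chloro-3-(trifluoromethyl)phenyl group of compound 3.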